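One carbon less on the chain, in two related cores

The source may report more compounds than this note shows. Statements on the series, on what has been measured and on what is new or still open speak of the compounds shown alone.

Compound 1 `COc1ccc(N(C)c2nc(C)nc3ccccc23)cc1OCCC[Se]C#N`: 852 nM
Compound 2 `COc1ccc(N(C)c2nc(C)nc3ccccc23)cc1OCCCC[Se]C#N`: 512 nM
Compound 3 `COc1ccc(N(C)c2nc(C)nc3ccccc23)cc1C(=O)OCCCCCC[Se]C#N`: 1990 nM

Of the compounds shown here, three have been measured in a functional assay on HCT-116 cells (Homo sapiens) for inhibition, read by MTT assay, with a stated time of 48 h; on this read-out lower numbers stand for stronger inhibition and higher numbers for weaker inhibition. Compound 2 gives 512 nM and compound 1 gives 852 nM; the step between them, a 1.7-fold higher number from compound 2 to compound 1 (0.22 log units; within the scatter), corresponds to the change (a group of 3 heavy atoms (1 carbon, 1 nitrogen, 1 selenium; no ring) in place of a group of 4 heavy atoms (2 carbon, 1 nitrogen, 1 selenium; no ring), on a saturated chain carbon, three bonds along the chain from an oxygen on an aromatic ring). Compound 3 gives 1990 nM in this assay, the highest of the three numbers, and the difference between its core and that of compound 2 is not broken down here.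

Compound 4 `COc1ccc(N(C)c2nc(C)nc3ccccc23)cc1C(=O)OCCCCC[Se]C#N` is not yet measured. It arises from compound 3 through (a group of 3 heavy atoms (1 carbon, 1 nitrogen, 1 selenium; no ring) in place of a group of 4 heavy atoms (2 carbon, 1 nitrogen, 1 selenium; no ring), on a saturated chain carbon, five bonds along the chain from an oxygen next to a carbonyl group). Within the data shown here, this is the same kind of change as the one from compound 2 to compound 1, but not the same: there it sits three bonds along the chain from an oxygen on an aromatic ring, here five bonds along the chain from an oxygen next to a carbonyl group. From compound 3 to compound 4 the step is expected to be a 1.4-fold higher number from compound 3 to compound 4 (0.15 log units; within the scatter), resting on the earlier step of a 1.7-fold higher number from compound 2 to compound 1 (0.22 log units; within the scatter), which lay within the scatter. Compound 4 is therefore estimated at 2800 nM in this assay, expected to fall between 1400 nM and 5600 nM.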

Compound 4, half-maximal inhibitory concentration: 551 nM
Compound 4: middle estimate off by 5.1-fold (0.71 log units), on the high side; the whole stated range lies above it.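

In this assay, the same change on the core of compound 3 gave a 3.6-fold lower number from compound 3 to compound 4 (0.56 log units; beyond the scatter), and this step does not match the one seen on the other core: the same change on two cores in this assay, a 1.7-fold higher number (0.22 log units; within the scatter) from compound 2 to compound 1 and a 3.6-fold lower number (0.56 log units; beyond the scatter) from compound 3 to compound 4, 6.0-fold (0.78 log units) apart, beyond the scatter of two such steps. This shows that, within this series, the result of the change on one core could not be carried over to the other, since the step read on one core gave no reliable guide to the step on the second. Among these compounds, it does not show what sets the two steps apart, as each core supplies only one pair, and the change sits three bonds along the chain from an oxygen on an aromatic ring in one pair and five bonds along the chain from an oxygen next to a carbonyl group in the other.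

The compounds shown leave open how a shorter chain on the core of compound 4 or a longer chain on the core of compound 2 would read. They also leave open whether the same contrast between the two cores would appear with a sulfur atom in place of the selenium.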